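Swapping butoxy for methyl: an expected step in cytotoxicity

The source may hold more compounds than are shown below. What is called first, only, known or untested is meant among the compounds shown, and "the series" means these compounds.

Measured so far in a functional assay on HL-60 cells (Homo sapiens) for cytotoxicity, read by WST assay, with a stated time of 48 h; a lower number here means that less compound is needed, a higher number that more compound is needed for the effect:
Compound 1 `Cc1cccc(C[C@H]2C(=O)OC[C@@H]2Cc2ccccc2)c1` gives 53000 nM
Compound 2 `O=C1OC[C@H](Cc2ccccc2)[C@H]1Cc1cccc(Cl)c1` gives 36000 nM
Compound 3 `CCCCOc1ccc(C[C@H]2C(=O)OC[C@@H]2Cc2ccccc2)cc1` gives 23000 nM

Compound 3 at 23000 nM lies within the scatter of compound 2 at 36000 nM and has a lower number than compound 1 at 53000 nM by more than the scatter. Compound 4 `Cc1ccc(C[C@H]2C(=O)OC[C@@H]2Cc2ccccc2)cc1` differs from compound 3 in one place, with methyl in place of butoxy on an aromatic carbon. Among the measured compounds shown here, only one measured step bears on this change, and only loosely. For the measured compounds named here, that step, chloro in place of methyl on an aromatic carbon (a 1.5-fold lower number from compound 1 to compound 2 (0.17 log units; within the scatter)), stays within the scatter, and no measured step removes butoxy. Going by the values given here, compound 1 also carries a methyl, at another place, and its value of 53000 nM gives the only guide. In this assay a modest move towards a higher number is therefore expected (a 2.0-fold higher number from compound 3 to compound 4 (0.29 log units; within the scatter)). For compound 4 the expected value is 45000 nM (estimated range 22000 nM to 90000 nM).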

Compound 4, half-maximal effective concentration: 44000 nM
Compound 4: middle estimate off by 1.0-fold (0.01 log units), on the high side; the range from low to high includes it.
By their numbers in this assay, from the lowest: compounds 3, 2, 4 and 1 (each within the scatter of the next, the first and the last beyond it).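

In this assay the exchange of butoxy for methyl can now be read directly at this place, on an aromatic carbon para to a large group, and it stays within the scatter (a 1.9-fold higher number from compound 3 to compound 4 (0.28 log units; within the scatter)). Among the compounds shown here, compound 4 also gives the first reading of a change in the methylphenyl group on the saturated chain carbon: 4-methylphenyl in place of 3-methylphenyl (a 1.2-fold lower number from compound 1 to compound 4 (0.08 log units; within the scatter)) and in place of 3-chlorophenyl (a 1.2-fold higher number from compound 2 to compound 4 (0.09 log units; within the scatter)) both stay within the scatter, so neither change separates these compounds in this assay. No outside evidence bears on these steps.

As far as these compounds go, it remains open whether an amine or a carboxylic acid at this place would give a step beyond the scatter. The same question stands for a chain longer than butoxy.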